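This account rests on a few compounds, and the source may have more. Where it says the series, first, only, none or still open, it means among the compounds named here.

Measured compounds:
compound 1 `CCCNc1ccc(NC(=O)c2cc(Cl)ccc2O)c(Cl)c1` gives 22500 nM in an ADME assay on A549 cells (Homo sapiens) for cytotoxicity, read by resazurin assay, with a stated time of 48 h; a lower number here means that less compound is tolerated, a higher number that more compound is tolerated;
compound 2 `O=C(Nc1ccc(NCc2ccc(F)cc2)cc1Cl)c1cc(Cl)ccc1O` gives 54400 nM in this assay.

Among the measured compounds shown here, compound 2 holds the highest of the two numbers so far, the only neighbour being compound 1, reached by a 2.4-fold higher number from compound 1 to compound 2 (0.38 log units; beyond the scatter). Compound 3 `O=C(Nc1ccc(NCc2cccc(Br)n2)cc1Cl)c1cc(Cl)ccc1O` is not yet measured; it differs from compound 2 in one place: 6-bromopyridin-2-yl in place of 4-fluorophenyl on a saturated chain carbon bound to a nitrogen on an aromatic ring. For the measured compounds named here, the sole measured step, a 2.4-fold higher number from compound 1 to compound 2 (0.38 log units; beyond the scatter), concerns a different change and so does not bear on this one. Going by the values given here, with no step to rely on, no shift beyond the scatter is expected in this assay, that is a 1.1-fold lower number from compound 2 to compound 3 (0.04 log units; within the scatter). Compound 3 is therefore estimated at 50000 nM, within 25000 nM to 100000 nM.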

Compound 3, half-maximal cytotoxic concentration: 92300 nM
For compound 3 the middle estimate is 1.8-fold (0.27 log units) below the measured one, and the stated range covers the measured number.
By their numbers in this assay, from the lowest: compound 1; then compounds 2 and 3 (each within the scatter of the next).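

In this assay, exchanging one aromatic ring for another at this position, on a saturated chain carbon bound to a nitrogen on an aromatic ring, gives a 1.7-fold higher number from compound 2 to compound 3 (0.23 log units; within the scatter) and so does not separate 6-bromopyridin-2-yl from 4-fluorophenyl. Set against ethyl, 6-bromopyridin-2-yl gives a 4.1-fold higher number from compound 1 to compound 3 (0.61 log units; beyond the scatter) and thus joins 4-fluorophenyl in standing clear of ethyl. The added ring nitrogen and the bromine, which enter together, cannot be read apart. On these data alone, whether a morpholine or a carboxylic acid at this position would fit the same picture stays open. Nothing available here accounts for the result.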